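A few compounds are considered here, and "the series" means these few. Any claim that something is new, unique, unknown or untested is made for them only; others in the source may bear on it.

Compounds measured so far:

compound 1 `CCCCCC/C(=N\OCCC)c1cc(OC)c2c(c1OC)C(=O)C=CC2=O` gives 0.166 ug/mL in a functional assay on L1210 cells (Mus musculus) for antiproliferative activity; a lower number here means that less compound is needed, a higher number that more compound is needed for the effect
compound 2 `CO/N=C/c1cc(OC)c2c(c1OC)C(=O)C=CC2=O` gives 0.109 ug/mL in this assay
compound 3 `COc1cc(/C=N/OCc2ccccc2)c(OC)c2c1C(=O)C=CC2=O` gives 0.264 ug/mL in this assay

Compound 1 stands second highest of the three numbers; its nearest neighbour is compound 2 and its furthest is compound 3, and both gaps lie within the scatter, so no order among them can be read. Compound 4 `CCCCCC/C(=N\OCCCCC)c1cc(OC)c2c(c1OC)C(=O)C=CC2=O` is not yet measured. It differs from compound 1 by ethyl in place of hydrogen on a saturated chain carbon, three bonds along the chain from an oxygen, so the chain on the oxime oxygen grows from propyl to pentyl. Going by the values given here, the only measured step that touches that chain is a 2.4-fold higher number from compound 2 to compound 3 (0.38 log units; beyond the scatter), where a phenyl, not an alkyl, enters on the carbon bound to the oxygen; lengthening the chain by ethyl three bonds out is a different change, and the data give no step for it. The account therefore expects at most a modest step in this assay, if any, towards a somewhat higher number. Compound 4 is estimated at 0.22 ug/mL with a range from 0.09 ug/mL to 0.55 ug/mL, which would mean a 1.3-fold higher number from compound 1 to compound 4 (0.12 log units; within the scatter).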

Compound 4, concentration for half-maximal effect: 0.224 ug/mL
For compound 4 the middle estimate is 1.0-fold (0.01 log units) below the measured one; measured number inside the range.
By their numbers in this assay, from the lowest: compounds 2, 1, 4 and 3 (each within the scatter of the next, the first and the last beyond it).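

In this assay the growth of the chain on the oxime oxygen from propyl to pentyl gives a 1.3-fold higher number from compound 1 to compound 4 (0.13 log units; within the scatter) and so adds no change that can be read. This is the first step among these compounds that stays purely alkyl at this position, and it shows that ethyl can stand on a saturated chain carbon, three bonds along the chain from an oxygen, with the number staying within the scatter. The earlier step, which put a phenyl on the carbon bound to the oxygen, could not show this. No supporting evidence bears on this result.

Going by these compounds, it remains open whether a longer chain such as octyl would also leave the number within the scatter. The same holds for an amine or a carboxylic acid in place of the pentyl chain.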